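The source may report more compounds than this note shows. Statements on the series, on what has been measured and on what is new or still open speak of the compounds shown alone.

Compound 1 `Cc1ccc(S(=O)(=O)/N=C(/CCNC2=CC(=O)c3ccccc3C2=O)Nc2ccccc2[N+](=O)[O-])cc1`: 69600 nM
Compound 2 `Cc1ccc(S(=O)(=O)/N=C(/CCNC2=CC(=O)c3ccccc3C2=O)Nc2cccc(C(F)(F)F)c2)cc1`: 91500 nM

In an ADME assay on HEK293 cells (Homo sapiens) for cytotoxicity, read by MTT assay, with a stated time of 48 h (a lower number here means a stronger inhibitor, a higher number a weaker inhibitor), compound 1 gives the lowest of the two numbers, with compound 2 nearest; the step of a 1.3-fold higher number from compound 1 to compound 2 (0.12 log units; within the scatter) is within the scatter. Compound 3 `Cc1ccc(S(=O)(=O)/N=C(/CCNC2=CC(=O)c3ccccc3C2=O)NC(C)C)cc1` differs from compound 1 by isopropyl in place of 2-nitrophenyl on an amine nitrogen. Among the measured compounds shown here, the one measured step swaps one six-membered aromatic ring of carbon only for another and so says little about replacing the ring with isopropyl. With no closer guide, no step beyond the scatter is expected in this assay, and compound 3 is estimated at 70000 nM (range 25000 nM to 200000 nM), an expected step of a 1.0-fold higher number from compound 1 to compound 3 (0.00 log units; within the scatter).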

Compound 3, half-maximal inhibitory concentration: 71600 nM
Estimate against measurement, compound 3: 1.0-fold (0.01 log units) below; low and high end bracket the measured number.
By their numbers in this assay, from the lowest: compounds 1, 3 and 2 (each within the scatter of the next).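

In this assay, the ring on the amine nitrogen can go without the number leaving the scatter: isopropyl gives a 1.0-fold higher number from compound 1 to compound 3 (0.01 log units; within the scatter) and also a 1.3-fold lower number from compound 2 to compound 3 (0.11 log units; within the scatter), so neither aromatic group differs measurably from this small group with no ring. Across these three compounds, then, this position tolerates a clear change in size and shape with no readable change in cytotoxicity. No measurement here explains this flat result. On these data alone, whether any group on this nitrogen can move the number beyond the scatter stays open. A carboxylic acid or a longer chain carrying an amine would test that.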